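The source may hold more compounds than are shown below. What is called first, only, known or untested is meant among the compounds shown, and "the series" means these compounds.

Among the measured compounds shown here, compound 2 `CCCS(=O)(=O)N1CCN(c2ccc(OCC3CCN(C(=O)OC(C)C)CC3)cn2)CC1` gives 300 nM in a functional assay on CHO-K1 cells for agonist activity at Glucose-dependent insulinotropic receptor (Homo sapiens), read by a luciferase reporter, with a stated time of 5 h (a higher number here means that more compound is needed for the effect, a lower number that less compound is needed), the lowest of the three numbers measured so far. Compound 1 `CC(C)OC(=O)N1CCC(COc2ccc(N3CCN(C(=O)c4ccco4)CC3)nc2)CC1` gives 1900 nM and compound 3 `CC(C)OC(=O)N1CCC(COc2ccc(N3CCN(S(=O)(=O)c4cccs4)CC3)nc2)CC1` gives 1800 nM; the steps of a 6.3-fold lower number from compound 1 to compound 2 (0.80 log units; beyond the scatter) and a 6.0-fold higher number from compound 2 to compound 3 (0.78 log units; beyond the scatter) lie beyond the scatter, while a 1.1-fold lower number from compound 1 to compound 3 (0.02 log units; within the scatter) lies within it. All three of those steps change the group on an amine nitrogen in a ring. Compound 4 `CCCS(=O)(=O)N1CCN(c2ccc(OCC3CCN(C(=O)c4ccco4)CC3)cn2)CC1` differs from compound 2 at a different place: furan-2-yl in place of isopropoxy on a carbonyl carbon. For the measured compounds named here, no measured step touches this carbonyl carbon, so no direction can be read from the data, and a step within the scatter is expected, a 1.2-fold higher number from compound 2 to compound 4 (0.07 log units; within the scatter). Compound 4 is therefore estimated at 350 nM, with a range from 120 nM to 1000 nM.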

Compound 4, half-maximal effective concentration: 2000 nM
The estimate for compound 4 lay 5.7-fold (0.76 log units) below the measured number, outside the stated range (above it).
By their numbers in this assay, from the lowest: compound 2; then compounds 3, 1 and 4 (each within the scatter of the next).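

The carbonyl carbon on the amide-type ring nitrogen is a sensitive position: in this assay, furan-2-yl in place of isopropoxy gives a 6.7-fold higher number from compound 2 to compound 4 (0.82 log units; beyond the scatter). The number therefore responds to a change at this end of the molecule too, not only to changes on the sulfonyl side. Nothing measured here bears on the cause of this step. Still open, from the compounds shown here alone, is whether a tert-butoxy or ethoxy group on this carbonyl carbon would keep the number of compound 2, and whether a non-aromatic cyclopentyl ring would behave like furan-2-yl.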